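Trading bromo for trifluoromethyl in a closely matched trio

The source may report more compounds than this note shows. Statements on the series, on what has been measured and on what is new or still open speak of the compounds shown alone.

Measured so far in a functional assay on A549 cells (Homo sapiens) for antiproliferative activity, read by MTT assay, with a stated time of 48 h; a lower number here means a stronger inhibitor, a higher number a weaker inhibitor:
- compound 1 `Fc1ccc2[nH]c(-c3cn(-c4ccccc4)nc3-c3ccccc3)nc2c1` gives 1720 nM
- compound 2 `Brc1ccc2[nH]c(-c3cn(-c4ccccc4)nc3-c3ccccc3)nc2c1` gives 1810 nM
- compound 3 `COc1ccc2[nH]c(-c3cn(-c4ccccc4)nc3-c3ccccc3)nc2c1` gives 1230 nM

At 1810 nM, compound 2 cannot be told apart from the other two compounds, since all of their differences are within the normal spread of repeat measurements. The next compound, compound 4 `FC(F)(F)c1ccc2[nH]c(-c3cn(-c4ccccc4)nc3-c3ccccc3)nc2c1`, carries trifluoromethyl in place of bromo on an aromatic carbon.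

The three measured compounds differ from one another only in the group at this same place, so their steps are the best available guide. They are a 1.1-fold higher number from compound 1 to compound 2 (0.02 log units; within the scatter), a 1.5-fold lower number from compound 2 to compound 3 (0.17 log units; within the scatter) and a 1.4-fold lower number from compound 1 to compound 3 (0.15 log units; within the scatter). Among the measured compounds shown here, no measured compound carries trifluoromethyl, so this guide is indirect and the range should stay wide. Even so, none of these exchanges moved the number in this assay beyond the scatter, so no clear shift in either direction is expected here. The expected change is a 1.1-fold lower number from compound 2 to compound 4 (0.05 log units; within the scatter). The estimated value for compound 4 is 1600 nM. Its expected range runs from 800 nM to 3200 nM.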

Compound 4, half-maximal inhibitory concentration: 5930 nM
Compound 4: middle estimate off by 3.7-fold (0.57 log units), on the low side, outside the stated range (above it).
By their numbers in this assay, from the lowest: compounds 3, 1 and 2 (each within the scatter of the next); then compound 4.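

In this assay, the earlier exchanges at this position left the number within the scatter, so the position could have seemed to tolerate any group. Trifluoromethyl shows that it does not. The change gives a 3.3-fold higher number from compound 2 to compound 4 (0.52 log units; beyond the scatter) and a 3.4-fold higher number from compound 1 to compound 4 (0.54 log units; beyond the scatter) and also a 4.8-fold higher number from compound 3 to compound 4 (0.68 log units; beyond the scatter), each a weaker result. Fluorine atoms alone do not mark out this change, since compound 1 also carries fluorine on this carbon and stays within the scatter of compound 2 and compound 3, and no measurement here explains why trifluoromethyl stands apart.

The compounds shown leave open whether this weaker result belongs to trifluoromethyl alone or would also appear with other groups here, such as a nitrile, an amine or a carboxylic acid. They also cannot say whether the same exchange would behave alike elsewhere on the shared core.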